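Difluoromethyl to Trifluoromethyl on Two Related Cores

The source may hold more compounds than are shown below. What is called first, only, known or untested is meant among the compounds shown, and "the series" means these compounds.

Compound 1, `Fc1cc2nc(-c3cncnc3C(F)F)n(C3CC3)c2cc1F`, was tested in an ADME assay on cells for inhibition of cytochrome P450 11B1, mitochondrial (Homo sapiens), read by HPLC, with a stated time of 60 min (on this read-out lower numbers stand for stronger inhibition and higher numbers for weaker inhibition), where compound 1 gives 4330 nM. Compound 2, `Fc1cc2nc(-c3cncnc3C(F)(F)F)n(C3CC3)c2cc1F`, carries the change fluoro in place of hydrogen on a saturated chain carbon bound to an aromatic carbon and two fluorine atoms relative to compound 1, and in this assay compound 2 gives 4770 nM; the step is a 1.1-fold higher number from compound 1 to compound 2 (0.04 log units; within the scatter). Compound 3, `N#Cc1ccc2nc(-c3cncnc3C(F)F)n(C3CC3)c2n1`, is built on a different core; the difference between the two cores is not broken down here. In this assay compound 3 gives 3930 nM, and the numbers of compound 1 and compound 3 sit within the scatter of each other.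

Compound 4, `N#Cc1ccc2nc(-c3cncnc3C(F)(F)F)n(C3CC3)c2n1`, has not yet been measured. It differs from compound 3 by fluoro in place of hydrogen on a saturated chain carbon bound to an aromatic carbon and two fluorine atoms, the same change that was made from compound 1 to compound 2, at a place described in the same words. Because the measured step of a 1.1-fold higher number from compound 1 to compound 2 (0.04 log units; within the scatter) stayed within the scatter, the expected step is a 1.1-fold higher number from compound 3 to compound 4 (0.04 log units; within the scatter), which rests on that single earlier pair alone. The estimate for compound 4 in this assay is therefore 4300 nM, expected to fall between 2500 nM and 7500 nM.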

Compound 4, half-maximal inhibitory concentration: 4810 nM
The estimate for compound 4 lay 1.1-fold (0.05 log units) below the measured number; the range from low to high includes it.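

In this assay, replacing difluoromethyl with trifluoromethyl on the core of compound 3 gives a 1.2-fold higher number from compound 3 to compound 4 (0.09 log units; within the scatter) and so leaves the reading unchanged within normal assay variation. The same change has now been read on two cores, and the two steps do not differ: the same change on two cores in this assay, a 1.1-fold higher number (0.04 log units; within the scatter) from compound 1 to compound 2 and a 1.2-fold higher number (0.09 log units; within the scatter) from compound 3 to compound 4, 1.1-fold (0.05 log units) apart, within the scatter of two such steps. This shows that, on these two cores, the change made no measurable difference in this assay, but it does not show that trifluoromethyl raises the number, since neither step lies beyond the scatter, and two small steps say nothing about how the change would behave on a third core.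

The compounds shown leave open how a plain methyl, an amine or a carboxylic acid would read in this assay if placed where the difluoromethyl sits. They also leave open whether any change at that place can move the number beyond the scatter, and whether such a larger step would then carry from one core to the other.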